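Lengthening a Saturated Chain on Compound 2

The source may report more compounds than this note shows. Statements on the series, on what has been measured and on what is new or still open speak of the compounds shown alone.

In a functional assay on MCF7 cells (Homo sapiens) for antiproliferative activity, read by MTT assay, with a stated time of 72 h (a higher number here means a weaker inhibitor, a lower number a stronger inhibitor), compound 2 `CCCCCCOc1ccc(C2=C(c3ccc(O)cc3)[C@H]3C[C@H](S(=O)(=O)N(CC)c4ccccc4)[C@@H]2O3)cc1` gives 3450 nM. Compound 1 `CCCCOc1ccc(C2=C(c3ccc(O)cc3)[C@H]3C[C@H](S(=O)(=O)N(CC)c4ccccc4)[C@@H]2O3)cc1` gives 3290 nM, within the scatter of compound 2. Compound 3 `CCCCCCCCOc1ccc(C2=C(c3ccc(O)cc3)[C@H]3O[C@@H]2C[C@@H]3S(=O)(=O)N(CC)c2ccccc2)cc1` gives 1160 nM, a lower number beyond the scatter of compound 2. Compound 2 therefore stands at the high end of these three numbers, level with compound 1.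

Compound 4 `CCCCCCCCOc1ccc(C2=C(c3ccc(O)cc3)[C@H]3C[C@H](S(=O)(=O)N(CC)c4ccccc4)[C@@H]2O3)cc1` differs from compound 2 by one change: ethyl in place of hydrogen on a saturated chain carbon, six bonds along the chain from an oxygen on an aromatic ring. This places ethyl in place of hydrogen on a saturated chain carbon, six bonds along the chain from an oxygen on an aromatic ring. Going by the values given here, the only measured step of this kind is a 1.0-fold higher number from compound 1 to compound 2 (0.02 log units; within the scatter), where the same replacement sits four bonds along the chain. An isomer of compound 4 is compound 3, at 1160 nM, which tilts the expectation slightly lower.

No step beyond the scatter is expected in this assay, and the estimated 1.4-fold lower number from compound 2 to compound 4 (0.16 log units; within the scatter) leans only mildly downward. Compound 4 is expected at 2400 nM, with an estimated range of 1100 nM to 5000 nM.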

Compound 4, half-maximal inhibitory concentration: 5890 nM
For compound 4 the middle estimate is 2.5-fold (0.39 log units) below the measured one; the measured number lies above the stated range.
By their numbers in this assay, from the lowest: compound 3; then compounds 1, 2 and 4 (each within the scatter of the next).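

In this assay, ethyl placed six bonds along the chain from the oxygen on the aromatic ring gives a 1.7-fold higher number from compound 2 to compound 4 (0.23 log units; within the scatter), and butyl placed four bonds along gives a 1.8-fold higher number from compound 1 to compound 4 (0.25 log units; within the scatter). Going by these compounds alone, the single earlier step covered only the position four bonds along, so these results extend the picture: among compound 1, compound 2 and compound 4, lengthening the chain to this extent produces no step beyond the scatter. Nothing in the available data explains why these three numbers stay within the scatter.

On these data alone, what sets compound 4 apart from its isomer, compound 3 at 1160 nM, remains open. As far as these compounds go, it is also open whether a longer chain, or a chain carrying an amine or a carboxylic acid, would give a step beyond the scatter.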